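Cytotoxicity readings in the ester series: step to the phenol

A few compounds are considered here, and "the series" means these few. Any claim that something is new, unique, unknown or untested is made for them only; others in the source may bear on it.

Compound 1 `CCOC(=O)c1c(-c2ccccc2)[nH]c2cc(OC)ccc2c1=O` gives, in an ADME assay on HepG2 cells (Homo sapiens) for cytotoxicity, read by luminescence, with a stated time of 72 h (a lower number here means that less compound is needed, a higher number that more compound is needed for the effect), a value of > 21500 nM, which is a limit of the assay and not a number.
Compound 2 `CCOC(=O)c1c(-c2cccc(C)c2)[nH]c2cc(OC)ccc2c1=O` gives in this assay the limit > 21500 nM.
Compound 3 `CCCOc1cccc(-c2[nH]c3cc(OC)ccc3c(=O)c2C(=O)OCC)c1` gives in this assay the limit > 21500 nM.

Compound 3 therefore stands only at a limit, and both other values are limits as well, as stated by the limit of > 21500 nM in this assay, at which 3 of the 3 values shown sit. The measured steps all run between limits: a step that the two limits leave unreadable from compound 1 to compound 2, a step that the two limits leave unreadable from compound 1 to compound 3 and a step that the two limits leave unreadable from compound 2 to compound 3 give no readable size, so they show only that none of the three compounds reaches a measurable effect within the tested range.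

Compound 4 `CCOC(=O)c1c(-c2cccc(O)c2)[nH]c2cc(OC)ccc2c1=O` differs from compound 3 by hydrogen in place of propyl on an oxygen on an aromatic ring. Within the data shown here, no measured step bears on this change with a readable size. Among the measured compounds shown here, the only guide is that every value so far, including that of compound 3, is a limit, so compound 4 is expected to behave alike, with the step that the limit leaves unreadable from compound 3 to compound 4 carrying no sign beyond the scatter. The estimate for compound 4 in this assay is therefore 30000 nM, with a range from 10000 nM to 100000 nM, and most likely the assay again reports only a limit.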

Compound 4, half-maximal effective concentration: > 21500 nM
Compound 4 was reported as a limit; the forecaster's own chance of this, stated with the estimate: 80%; the middle value lies beyond the limit too.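

Compound 4 gives > 21500 nM in this assay, which is again a limit of the assay, so no step among compound 1, compound 2, compound 3 and compound 4 can be read: the limit of > 21500 nM in this assay, at which 4 of the 4 values shown sit.

The compounds shown leave open whether any change to the shared core brings a measurable effect in this assay.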